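The source may report more compounds than this note shows. Statements on the series, on what has been measured and on what is new or still open speak of the compounds shown alone.

Compound 1, `Cc1c(C(=O)Nc2ccc(Oc3ncnc4[nH]cc(-c5ccccc5)c34)c(F)c2)c(=O)c2cc(C(F)(F)F)ccc2n1C`: 150 nM
Compound 2, `CCCc1ccc2c(c1)c(=O)c(C(=O)Nc1ccc(Oc3ncnc4[nH]cc(-c5ccccc5)c34)c(F)c1)c(C)n2C`: 61 nM

In an assay on isolated protein for inhibition of tyrosine-protein kinase receptor UFO (Homo sapiens), read by FRET and Z'-LYTE, with a stated time of 1.5 h (a higher number here means a weaker inhibitor, a lower number a stronger inhibitor), compound 2 stands lowest of the two numbers measured, and its nearest neighbour is compound 1. Among the compounds with values here, the single step seen so far is a 2.5-fold lower number from compound 1 to compound 2 (0.39 log units; beyond the scatter). Compound 3, `COc1ccc2c(c1)c(=O)c(C(=O)Nc1ccc(Oc3ncnc4[nH]cc(-c5ccccc5)c34)c(F)c1)c(C)n2C`, differs from compound 2 by methoxy in place of propyl on an aromatic carbon. Within the data shown here, no measured step covers methoxy at this carbon, so the only guide is that exchange of the group at this carbon mattered modestly. Because a 2.5-fold lower number from compound 1 to compound 2 (0.39 log units; beyond the scatter) was modest, the expected step of a 1.6-fold higher number from compound 2 to compound 3 (0.21 log units; within the scatter) is small, toward a higher number, and may fall within the scatter. Compound 3 is therefore estimated at 100 nM, within a range of 40 nM to 250 nM.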

Compound 3, half-maximal inhibitory concentration: 99 nM
The estimate for compound 3 lay 1.0-fold (0.00 log units) above the measured number, within the range that was stated.
By their numbers in this assay, from the lowest: compounds 2, 3 and 1 (each within the scatter of the next, the first and the last beyond it).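

In this assay methoxy, which brings an oxygen and a hydrogen-bond acceptor to this aromatic carbon, cannot be told apart from either earlier group: propyl (a 1.6-fold higher number from compound 2 to compound 3 (0.21 log units; within the scatter)) or trifluoromethyl (a 1.5-fold lower number from compound 1 to compound 3 (0.18 log units; within the scatter)). Only the propyl and trifluoromethyl compounds are separated from each other, so three quite different groups at this carbon give numbers close together. No measurement given here explains these numbers. Going by these compounds, whether an amine, a carboxylic acid or a longer chain at this carbon would stay this close remains open.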